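Replacing a methylpyrazole with fluorophenyl on a sulfonamide scaffold

A few compounds are considered here, and "the series" means these few. Any claim that something is new, unique, unknown or untested is made for them only; others in the source may bear on it.

The account covers two measured compounds and one unmeasured analogue sharing the same core. Among the compounds with values here, compound 1 `O=S(=O)(Nc1ccncn1)c1ccc2c(c1)OCC[C@@H]2c1ccc(C(F)(F)F)cc1-c1ccc(F)cn1` is the first of the pair; in a physicochemical assay for solubility (on this read-out lower numbers stand for lower solubility and higher numbers for higher solubility), compound 1 gives 181000 nM. Compound 2 `Cn1nccc1-c1cc(C(F)(F)F)ccc1[C@@H]1CCOc2cc(S(=O)(=O)Nc3nccs3)ccc21` is the second; in this assay compound 2 gives 65000 nM, which is the lower of the two numbers, and the gap between compound 2 and compound 1 lies beyond the scatter of the method. Compound 3 `O=S(=O)(Nc1nccs1)c1ccc2c(c1)OCC[C@H]2c1ccc(C(F)(F)F)cc1-c1ccc(F)cc1` has not yet been measured in this assay. Compound 3 differs from compound 2 in one place: 4-fluorophenyl in place of 1-methyl-1H-pyrazol-5-yl on an aromatic carbon. Within the data shown here, since no measured pair in this set differs in exactly one place, no measured step can be used to calibrate the change. The expectation is nevertheless that the step of a 2.6-fold lower number from compound 2 to compound 3 (0.41 log units; beyond the scatter) points downward by a moderate amount, beyond the scatter, on the grounds that compound 2 already sits at the lower end of the measured values at 65000 nM. On that basis compound 3 is estimated to give 25000 nM in this assay, within a range from 8000 nM to 70000 nM.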

Compound 3, solubility: 147000 nM
Estimate against measurement, compound 3: 5.9-fold (0.77 log units) below; the measured number lies above the stated range.
By their numbers in this assay, from the lowest: compound 2; then compounds 3 and 1 (each within the scatter of the next).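

In this assay, within the data shown here, the exchange of 1-methyl-1H-pyrazol-5-yl for 4-fluorophenyl, on an aromatic carbon ortho to a large group and meta to a trifluoromethyl group, gives a 2.3-fold higher number from compound 2 to compound 3 (0.35 log units; beyond the scatter) and so provides the first step in this set that changes one place only. The step is modest but beyond the scatter, and it shows that at this position a six-membered aromatic ring of carbon only, with 0 hydrogen-bond acceptors, can stand in for a five-membered aromatic ring with 2 hetero atoms and 2 hydrogen-bond acceptors without the number falling. Nothing measured in this set bears on why the number moves in this direction, so the step stands as an observation.

The compounds shown leave open what an amine, a carboxylic acid or a simple methyl group would give on this same aromatic carbon, since both groups compared here are aromatic rings. They also leave open whether the exchange gives a step of similar size and direction when the sulfonamide carries the other ring found in compound 1.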